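Cytotoxicity notes: pyridin-2-yl in place of benzyl

This account rests on a few compounds, and the source may have more. Where it says the series, first, only, none or still open, it means among the compounds named here.

Measured in a toxicity assay on cells (Macrophage, Mus musculus, strain BALB/c) for cytotoxicity, read by MTT assay; a lower number here means a stronger inhibitor, a higher number a weaker inhibitor
- compound 1 `C=CCOc1cc(OC)c(C(=O)/C=C/Cc2ccccc2)c(OCC=C)c1` gives 14800 nM
- compound 2 `COc1ccc(/C=C/C(=O)c2c(O)cc(O)cc2OC)cc1` gives 166000 nM

Compound 1 holds the lower of the two numbers, and the gap up to compound 2 lies beyond the usual scatter. Compound 3 `C=CCOc1cc(OC)c(C(=O)/C=C/c2ccccn2)c(OCC=C)c1` has not yet been measured. It departs from compound 1 in one place, with pyridin-2-yl in place of benzyl on a double-bonded chain carbon bound to a double-bonded chain carbon and nothing else altered. Going by the values given here, no measured pair shows a single change, so the expectation starts from compound 1 at 14800 nM and takes compound 2 at 166000 nM as a loose upper reference. In this assay a modest step to a higher number, close to the edge of the scatter, is expected. The estimated step is a 1.7-fold higher number from compound 1 to compound 3 (0.23 log units; within the scatter) in that direction. For compound 3 the expected value is 25000 nM with an estimated range from 8000 nM to 80000 nM as the likely span.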

Compound 3, half-maximal inhibitory concentration: 12500 nM
For compound 3 the middle estimate is 2.0-fold (0.30 log units) above the measured one; low and high end bracket the measured number.
By their numbers in this assay, from the lowest: compounds 3 and 1 (each within the scatter of the next); then compound 2.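

Going by these compounds alone, at the place on a double-bonded chain carbon bound to a double-bonded chain carbon, pyridin-2-yl in place of benzyl gives a 1.2-fold lower number from compound 1 to compound 3 (0.07 log units; within the scatter) in this assay, the first single-place pair, and no separable difference appears. The entering group brings a ring nitrogen and a hydrogen-bond acceptor that benzyl lacks, yet this cytotoxicity read-out does not tell the two groups apart at this place. Nothing on hand accounts for this outcome.

Going by these compounds, whether pyridin-4-yl, an amine, a carboxylic acid or a longer chain at this place would move the number beyond the scatter remains open. Compound 2 differs from compound 1 and compound 3 in more than one place, so it gives no reading on this position.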